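The source may report more compounds than this note shows. Statements on the series, on what has been measured and on what is new or still open speak of the compounds shown alone.

Compound 1 `CNC(=O)c1cc(C(=O)NCCCC2CNCCO2)cn(Cc2ccccc2)c1=O`: >= 194 ug/mL
Compound 2 `CNC(=O)c1cc(C(=O)NC2CC2)cn(Cc2cccc(F)c2)c1=O`: >= 133 ug/mL

In a physicochemical assay for solubility (a lower number here means a less soluble compound, a higher number a more soluble compound), compound 1 gives >= 194 ug/mL, which is a limit of the assay rather than a number. In this assay compound 2 likewise gives only a limit, >= 133 ug/mL. Neither value fixes compound 1 at a point; it stands at the top of what this assay reports.

Compound 3 `CNC(=O)c1cc(C(=O)NCCC(C)C)cn(Cc2ccccc2)c1=O` differs from compound 1 by isopropyl in place of (morpholin-2-yl)methyl on a saturated chain carbon, two bonds along the chain from an amide-type nitrogen. Among the compounds with values here, no measured pair shows this change, so the expectation rests on the change itself. The step from compound 1 to compound 3 is expected to be a fall beyond the scatter, an at least 4.8-fold lower number from compound 1 to compound 3 (0.68 log units; beyond the scatter). Compound 3 is estimated at 40 ug/mL, expected between 10 ug/mL and 150 ug/mL.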

Compound 3, solubility: 10 ug/mL
The estimate for compound 3 lay 4.0-fold (0.60 log units) above the measured number; measured number inside the range.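

In this assay the change of (morpholin-2-yl)methyl to isopropyl on a saturated chain carbon, two bonds along the chain from an amide-type nitrogen, gives an at least 19-fold lower number from compound 1 to compound 3 (1.28 log units; beyond the scatter) and shows that this place in the chain is not indifferent to the group it carries. Compound 1 stands at a limit of the assay, so the step gives only a minimum size: the limit of >= 194 ug/mL in this assay, at which 1 of the 3 values shown sits.

The compounds shown leave open whether the fall follows the ring nitrogen, the ring oxygen or the ring as a whole. A piperidin-2-ylmethyl or tetrahydropyran-2-ylmethyl group at this place would separate these.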